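Amine aryl swap: from compound 3 to compound 4

This account rests on a few compounds, and the source may have more. Where it says the series, first, only, none or still open, it means among the compounds named here.

In a functional assay on ECa-109 cells for inhibition, with ECa-109 cell line (Homo sapiens) as the target, read by sulforhodamine B assay (a higher number here means a weaker inhibitor, a lower number a stronger inhibitor), the series shares one core and varies the group on the amine nitrogen. Compound 1 `O=C1C(NC2CCCC2)=CC(=O)c2c1nc1n2[C@H]2OC[C@@H](O)[C@H]2OC1`, the cyclopentyl member, gives > 16000 nM, which is a limit of the assay. Compound 2 `O=C1C(Nc2ccc(Br)cc2)=CC(=O)c2c1nc1n2[C@H]2OC[C@@H](O)[C@H]2OC1`, the 4-bromophenyl member, gives a true number of 1980 nM. Compound 3 `COc1ccccc1NC1=CC(=O)c2c(nc3n2[C@H]2OC[C@@H](O)[C@H]2OC3)C1=O`, the 2-methoxyphenyl member, gives > 4000 nM, and this too is only a limit.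

The next change leads to compound 4 `CCCc1ccc(NC2=CC(=O)c3c(nc4n3[C@H]3OC[C@@H](O)[C@H]3OC4)C2=O)cc1`: 4-propylphenyl in place of 2-methoxyphenyl on an amine nitrogen. In words, 4-propylphenyl replaces 2-methoxyphenyl on the amine nitrogen.

Among the measured compounds shown here, two measured steps bear on this change. The first is an at least 8.0-fold lower number from compound 1 to compound 2 (0.90 log units; beyond the scatter). The second is an at least 2.0-fold higher number from compound 2 to compound 3 (0.30 log units; that floor lies within the scatter). Compound 3 goes against any reading that an aryl group alone is enough, so the 4-bromophenyl result cannot be generalised to all aryl groups. Compound 2 remains the nearest guide, since its group also carries a substituent named at the 4 position, though a single pair supports this only weakly. A modest move to a lower number than compound 3 is therefore expected, with a real chance of another limit. The expected step is an at least 1.6-fold lower number from compound 3 to compound 4 (0.20 log units; that floor lies within the scatter). For compound 4 the estimated value is 2500 nM, with an expected range of 800 nM to 8000 nM.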

Compound 4, half-maximal inhibitory concentration: > 4000 nM
Compound 4: only a limit was reported; the forecaster's own chance of this, stated with the estimate: 30%; middle value at least 1.6-fold (0.20 log units) away from the limit.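

In this assay compound 4 gives > 4000 nM, and this is a limit of the assay. Among the compounds shown here, the one readable new step is an at least 2.0-fold higher number from compound 2 to compound 4 (0.30 log units; that floor lies within the scatter), so propyl in place of bromo on an aromatic carbon does not reproduce the true number of compound 2, yet the size of any loss cannot be told from this pair. The steps to compound 4 from compound 1 and from compound 3 cannot be read, as both ends of each are limits, and compound 2 is now the only member shown with a true number, so 4-propylphenyl goes against any reading that a substituted phenyl on the amine nitrogen is enough.

On these data alone, whether the true number of compound 2 belongs to bromo in particular stays open, and 4-chlorophenyl or 4-methylphenyl on the same amine nitrogen would bear on that. The order among the compounds at the limit also stays open, since no true number exists for them: the limit of > 4000 nM in this assay, at which 2 of the 4 values shown sit.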